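The source may report more compounds than this note shows. Statements on the series, on what has been measured and on what is new or still open speak of the compounds shown alone.

In a functional assay on CHO-K1 cells with Glucose-dependent insulinotropic receptor (Homo sapiens) as the target, read by a luciferase reporter, with a stated time of 5 h (on this read-out lower numbers stand for smaller maximal responses and higher numbers for larger maximal responses), compound 1 `CC(C)(C)OC(=O)N1CCC(Oc2ncnc3c2CCN3c2ccc(S(C)(=O)=O)cc2F)CC1` gives 139%.
Compound 2 `CC(C)(C)COC(=O)N1CCC(Oc2ncnc3c2CCN3c2ccc(S(C)(=O)=O)cc2F)CC1` gives 80%.
Compound 3 `CCSC(=O)N1CCC(Oc2ncnc3c2CCN3c2ccc(S(C)(=O)=O)cc2F)CC1` gives 128%.

Among these three numbers compound 3 stands second highest. Its nearest neighbour is compound 1, reached by the step of a number 11 percentage points lower from compound 1 to compound 3 (beyond the scatter); its furthest is compound 2, reached by the step of a number 48 percentage points higher from compound 2 to compound 3 (beyond the scatter). Both of those steps change only the group attached to the carbonyl carbon on the ring nitrogen, and they show that this position matters: exchanging tert-butoxy for neopentyloxy gave a number 59 percentage points lower from compound 1 to compound 2 (beyond the scatter), a large drop, while the ethylsulfanyl group kept the response close to that of compound 1.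

Compound 4 `CC(C)S(=O)(=O)N1CCC(Oc2ncnc3c2CCN3c2ccc(S(C)(=O)=O)cc2F)CC1` carries a different kind of group at the same ring nitrogen: isopropylsulfonyl in place of (ethylsulfanyl)carbonyl on an amine nitrogen in a ring. For the measured compounds named here, no measured pair here involves a sulfonyl group on that nitrogen, so the measured steps only show how wide the spread at this position can be, not where a sulfonyl will land. Compound 4 is therefore expected near the middle of the observed band, with a wide margin in either direction, giving an estimated step of a number 18 percentage points lower from compound 3 to compound 4 (beyond the scatter). The estimate for compound 4 is 110%, with a range from 65% to 150%.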

Compound 4, largest response reached (reported as percent of maximum), in percent of the reference or control that the assay uses: 62%
Compound 4: the middle estimate sits 48 percentage points above what was measured, outside the stated range (below it).
By their numbers in this assay, from the lowest: compound 4; then compound 2; then compound 3; then compound 1.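

Until now, only the group on the carbonyl had changed; compound 4 replaces the carbonyl link on the ring nitrogen itself, and in this assay this gives the lowest number of the four. The fall is large against the two highest compounds, with a number 66 percentage points lower from compound 3 to compound 4 (beyond the scatter) and a number 77 percentage points lower from compound 1 to compound 4 (beyond the scatter), so the response at this position can drop well below anything the carbonyl series had shown. Even the lowest carbonyl compound stays above the sulfonyl, though the gap is only modest, with a number 18 percentage points lower from compound 2 to compound 4 (beyond the scatter), and since compound 2 had already reached a low number with its carbonyl link intact, losing that link is not needed for a weak maximal response.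

No measurement available here explains why the isopropylsulfonyl group gives this low response. From the compounds shown here alone, it also remains open whether the low number belongs to the sulfonyl link or to the isopropyl on it: a methylsulfonyl group, or an isopropyl carbamate that puts the same branched chain on a carbonyl, would help separate the two.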